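This account rests on a few compounds, and the source may have more. Where it says the series, first, only, none or still open, it means among the compounds named here.

In an ADME assay on RAW264.7 cells (Mus musculus) for cytotoxicity (a lower number here means a stronger inhibitor, a higher number a weaker inhibitor), compound 1 `CCCc1nn(C)c2c(NCC(C)C)nc(/C=C/c3ccccc3)nc12` gives > 50000 nM, which is a limit of the assay and not a number. Compound 2 `CCCc1nn(C)c2c(N3CCC(O)CC3)nc(/C=C/c3cc(OC)c(OC)c(OC)c3)nc12` gives > 50000 nM, again only a limit. Compound 3 `CCCc1nn(C)c2c(N3CCCC3)nc(-c3cc(OC)c(OC)c(OC)c3)nc12` gives > 50000 nM, also only a limit. Compound 1 therefore shares (the limit of > 50000 nM in this assay, at which 3 of the 3 values shown sit), and no exact value is known for any of the three. Compound 4 `CCCc1nn(C)c2c(NC(C)C)nc(/C=C/c3ccccc3)nc12` keeps the core of compound 1 but has isopropyl in place of isobutyl on a nitrogen on an aromatic ring. Going by the values given here, no measured pair shows a single change of this kind. The expectation rests on compound 1 at > 50000 nM, a limit, and no step beyond the scatter is expected in either direction. The expected step is a number no higher from compound 1 to compound 4 (the limit leaves the size open). Compound 4 is estimated at 50000 nM, with an expected range of 20000 nM to 100000 nM.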

Compound 4, half-maximal inhibitory concentration: > 50000 nM
Compound 4: a limit, no number; the forecaster's own chance of this, stated with the estimate: 75%; the middle value sits exactly at the limit.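

Compound 1 and compound 4 each give only a limit, so no step can be read between them. The compounds shown leave open the exact value of each one, and whether swapping isobutyl for isopropyl changes anything: the limit of > 50000 nM in this assay, at which 4 of the 4 values shown sit.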